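Benzyl variation on the shared core: toward compound 4

This account rests on a few compounds, and the source may have more. Where it says the series, first, only, none or still open, it means among the compounds named here.

Three compounds of the series have numbers in a functional assay (B cells) with Mus musculus as the target; on this read-out higher numbers stand for an effect only at larger amounts of compound and lower numbers for an effect already at smaller amounts. Compound 1 `CCCn1c(=O)n(C2CCC(COC(C)=O)O2)c2nc(NC(C)=O)nc(O)c21` gives 154 uM, compound 2 `COc1ccc(Cn2c(=O)n(C3OC(CO)[C@@H](O)[C@H]3O)c3nc(N)nc(O)c32)cc1` gives 135 uM, and compound 3 `C=CCn1c(=S)n(C2OC(CO)[C@@H](O)[C@H]2O)c2nc(N)nc(O)c21` gives 1 uM. Compound 2 stands second highest of the three; its number and that of compound 1 lie within the scatter of each other, while the number of compound 3 lies far lower, beyond the scatter. Compound 4 `Nc1nc(O)c2c(n1)n(C1OC(CO)[C@@H](O)[C@H]1O)c(=O)n2Cc1ccccc1` has not yet been measured in this assay. It differs from compound 2 in one place: hydrogen in place of methoxy on an aromatic carbon. Within the data shown here, no pair of measured compounds shows this change, so no measured step guides it; a step that stays within the scatter, in either direction, is expected. For compound 4 the estimate is 120 uM, with a range from 40 uM to 400 uM. The expected step is thus a 1.1-fold lower number from compound 2 to compound 4 (0.05 log units; within the scatter).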

Compound 4, concentration for half-maximal effect: 6 uM
Compound 4: middle estimate off by 20-fold (1.30 log units), on the high side; the whole stated range lies above it.
By their numbers in this assay, from the lowest: compound 3; then compound 4; then compounds 2 and 1 (each within the scatter of the next).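

Going from 4-methoxybenzyl to benzyl gives a 23-fold lower number from compound 2 to compound 4 (1.35 log units; beyond the scatter) in this assay, the only one-place step shown in the series. This position on the aromatic ring, para to a large group, therefore bears strongly on the read-out, and the change involves methoxy and hydrogen alone. No measurement shown gives a reason for the size of this step.

From the compounds shown here alone, how an amine or a carboxylic acid at this position would compare remains open. Also open, going by these compounds, is whether the step would persist with a longer chain in place of the benzyl methylene.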